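Cycloheptyloxy in place of hexyloxy: clearance notes

The compounds below may be only part of what the source reports. "The series", "measured", "known", "first", "only" and "open" are said of these compounds alone.

Measured in an ADME assay on microsomes from liver (Homo sapiens) for metabolic stability, read by LC-MS, using NADPH, with a stated time of 60 min; on this read-out higher numbers stand for fast clearance and lower numbers for slow clearance:
compound 1 `CCCCc1ccc(-c2nc(C)c(/C(C)=N/NC(=N)N)s2)cc1`: 80.3 mL.min-1.g-1
compound 2 `CCCCOc1ccc(-c2nc(C)c(/C(C)=N/NC(=N)N)s2)cc1`: < 9.6 mL.min-1.g-1 (a limit)
compound 3 `CCCCCCOc1ccc(-c2nc(C)c(/C(C)=N/NC(=N)N)s2)cc1`: < 9.6 mL.min-1.g-1 (a limit)

Compound 3 stands at < 9.6 mL.min-1.g-1, which is a limit of the assay and not a number. Compound 2 and compound 3 share (the limit of < 9.6 mL.min-1.g-1 in this assay, at which 2 of the 3 values shown sit), and only compound 1 gives a number.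

The next structure is compound 4 `C/C(=N\NC(=N)N)c1sc(-c2ccc(OC3CCCCCC3)cc2)nc1C`, with the change (cycloheptyl in place of hexyl on an oxygen on an aromatic ring). In short, this is cycloheptyl in place of hexyl on an oxygen on an aromatic ring.

Among the compounds with values here, three measured steps bear on it. Butoxy in place of butyl gave an at least 8.3-fold lower number from compound 1 to compound 2 (0.92 log units; beyond the scatter), and hexyloxy in place of butyl gave an at least 8.3-fold lower number from compound 1 to compound 3 (0.92 log units; beyond the scatter). Ethyl in place of hydrogen on the chain gave a step that the two limits leave unreadable from compound 2 to compound 3, so the effect of extending the chain on the oxygen cannot be sized. Within the data shown here, no measured compound carries a ring on that oxygen, which leaves the expectation loose. In this assay, no change beyond the scatter is expected, although a modest rise remains possible. The expected step is a step that the limit leaves unreadable from compound 3 to compound 4. For compound 4 the estimated value is 9 mL.min-1.g-1, with an expected range of 4 mL.min-1.g-1 to 35 mL.min-1.g-1.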

Compound 4, intrinsic clearance in microsomes: < 9.6 mL.min-1.g-1
Compound 4 was reported as a limit (the forecaster's own chance of this, stated with the estimate: 65%); the middle value lies beyond the limit too.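

In this assay, compound 4 gives < 9.6 mL.min-1.g-1, which is a limit of the assay and not a number, so a seven-membered ring on the oxygen leaves the value at a limit, as the open hexyl and butyl chains did. Cycloheptyloxy in place of butyl gave an at least 8.3-fold lower number from compound 1 to compound 4 (0.92 log units; beyond the scatter), so the drop seen with the two open chains on that oxygen now also holds with a ring there. The steps to compound 4 from compound 2 and from compound 3 cannot be read, and the series now gathers at a single limit: the limit of < 9.6 mL.min-1.g-1 in this assay, at which 3 of the 4 values shown sit.

As far as these compounds go, whether butyl, hexyl and cycloheptyl on the oxygen differ at all stays open, as does how far past the limit any of compound 2, compound 3 and compound 4 lies. Also open, from the compounds shown here alone, is what a methyl on that oxygen, or an amine on the cycloheptyl ring, would give in this assay, and whether either would bring the read-out back to a number.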